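The compounds below may be only part of what the source reports. "The series", "measured", "known", "first", "only" and "open" are said of these compounds alone.

Of the compounds shown here, three of a shared core have been measured in a functional assay on A549 cells (Homo sapiens) for antiproliferative activity, read by MTT assay, with a stated time of 48 h; on this read-out higher numbers stand for weaker inhibition of growth and lower numbers for stronger inhibition of growth. Compound 1 `Cc1ccc(OCCCCN(Cc2ccc(C(=O)NO)cc2)c2ncc(-c3ccc(C)cc3)s2)cc1` gives 8630 nM, compound 2 `CCCN(Cc1ccc(C(=O)NO)cc1)c1ncc(-c2ccc(C)cc2)s1` gives 3310 nM, and compound 3 `Cc1ccc(-c2cnc(N(CCCCOc3ccccc3)Cc3ccc(C(=O)NO)cc3)s2)cc1` gives 14200 nM. Compound 3 thus has the highest number of the three; its gap to compound 1 lies within the scatter, while its gap to compound 2 lies beyond it.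

Compound 4 `Cc1ccc(-c2cnc(N(Cc3ccccc3)Cc3ccc(C(=O)NO)cc3)s2)cc1` differs from compound 3 in one place: phenyl in place of 3-phenoxypropyl on a saturated chain carbon bound to a nitrogen on an aromatic ring. The measured steps that bear on this are those where the longer chain with its aromatic ring was removed or added. The step of a 2.6-fold lower number from compound 1 to compound 2 (0.42 log units; beyond the scatter) and the step of a 4.3-fold higher number from compound 2 to compound 3 (0.63 log units; beyond the scatter) both show that the shorter substituent on the chain carbon goes with the lower number. Compound 4 keeps an aromatic ring but on a much shorter chain, so a modest drop toward the value of compound 2 is expected in this assay, with the step expected to be a 3.2-fold lower number from compound 3 to compound 4 (0.50 log units; beyond the scatter). The value for compound 4 is therefore estimated at 4500 nM, with a range from 1500 nM to 13000 nM.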

Compound 4, concentration for 50% growth inhibition: 4410 nM
Beside the measured number, compound 4's estimate is 1.0-fold (0.01 log units) above it; measured number inside the range.
By their numbers in this assay, from the lowest: compounds 2, 4, 1 and 3 (each within the scatter of the next, the first and the last beyond it).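

In this assay, replacing 3-phenoxypropyl with phenyl on the saturated chain carbon bound to a nitrogen on an aromatic ring gives a 3.2-fold lower number from compound 3 to compound 4 (0.51 log units; beyond the scatter) and so shows that the aromatic ring can stay at this position without the number staying high. With phenyl here the number is not told apart from that with ethyl, as the step of a 1.3-fold higher number from compound 2 to compound 4 (0.12 log units; within the scatter) lies within the scatter, and the same holds for the 3-(4-methylphenoxy)propyl group in the step of a 2.0-fold lower number from compound 1 to compound 4 (0.29 log units; within the scatter) even though the two groups differ greatly in length. No measurement is available that explains these results.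

From the compounds shown here alone, it remains open whether a 2-phenylethyl group would read like phenyl or like 3-phenoxypropyl at this position. Also open, going by these compounds, is how a chain ending in an amine or a carboxylic acid would compare with these groups.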